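Bromo to methoxy on the aryl ring of the core

This account rests on a few compounds, and the source may have more. Where it says the series, first, only, none or still open, it means among the compounds named here.

Compound 1 `N#CC1=C(N)OC(c2c[nH]c3ccccc23)=C(C#N)C1c1ccc(Br)cc1` is one of two compounds in the series with a number in a functional assay, tested at 100 ug/mL; on this read-out lower numbers stand for a weaker effect and higher numbers for a stronger effect at the one concentration tested; compound 1 gives 14.6%. Its nearest neighbour is compound 3 `Cc1ccc(C2C(C#N)=C(N)OC(c3c[nH]c4ccccc34)=C2C#N)cc1`, which in this assay gives 5.5%; the step of a number 9.1 percentage points lower from compound 1 to compound 3 (within the scatter) is within the scatter, so the two numbers cannot be told apart. Compound 2 `N#CC1=C(N)OC(c2c[nH]c3ccccc23)=C(C#N)C1c1ccc2ccccc2c1` is reported in this assay as "not active" (no number reported), without a number.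

Compound 4 `COc1ccc(C2C(C#N)=C(N)OC(c3c[nH]c4ccccc34)=C2C#N)cc1` differs from compound 1 by methoxy in place of bromo on an aromatic carbon.

Going by the values given here, the only measured step that bears on this change is the exchange at the same aromatic carbon, methyl in place of bromo, a number 9.1 percentage points lower from compound 1 to compound 3 (within the scatter), which stays within the scatter. One step of one kind gives no basis for expecting a move beyond the scatter, in either direction, when methoxy enters in place of bromo. The expected step is therefore a number 4.6 percentage points lower from compound 1 to compound 4 (within the scatter), nothing beyond the scatter.

Compound 4 is thus estimated in this assay at 10%, with a range from 0% to 25%; the report of compound 2 without a number shows that a result without a number is also possible.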

Compound 4, a percentage reported as activity, at one concentration (the size of the read-out at that concentration, not a potency): 20%
Compound 4: middle estimate off by 10 percentage points, on the low side, within the range that was stated.
By their numbers in this assay, from the lowest: compounds 3, 1 and 4 (each within the scatter of the next, the first and the last beyond it).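

In this assay, the exchange of bromo for methoxy on the aromatic carbon gives a number 5.4 percentage points higher from compound 1 to compound 4 (within the scatter) and so leaves 4-bromophenyl and 4-methoxyphenyl indistinguishable on this read-out. Going by these compounds alone, the exchange of methyl for methoxy at the same place gives a number 14.5 percentage points higher from compound 3 to compound 4 (beyond the scatter) and is, though modest, the first step to pass beyond the scatter, which shows that this position can separate two small groups in this assay even though compound 1 lies within the scatter of both compound 3 and compound 4. This rests on a single pair, and no supporting measurement accompanies the result that could account for it.

Open, on these data alone, is whether an amine, a carboxylic acid or a longer alkoxy chain at this same aromatic carbon would give a number beyond the scatter of compound 4, or a report without a number like that of compound 2. Also open, as far as these compounds go, is whether the gap between methyl and methoxy holds on any change to the shared core, since every compound here carries that core unchanged.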